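Hydroxy on the acetamido chain of compound 2

The source may report more compounds than this note shows. Statements on the series, on what has been measured and on what is new or still open speak of the compounds shown alone.

Among the compounds with values here, compound 2 (`C=C(c1cc(OC)c(OC)c(OC)c1)c1ccc(OC)c(O)c1NC(C)=O`) gives 80 nM in a functional assay on A549 cells (Homo sapiens) for antiproliferative activity, read by MTT assay, with a stated time of 48 h (on this read-out lower numbers stand for stronger inhibition and higher numbers for weaker inhibition), and holds the lower of the two numbers so far. Compound 1 (`C=C(c1ccc(OC)cc1NC(=O)CN(C)C)c1ccc(OC)c2c1OC(C)(C)C=C2`) gives 270 nM in this assay and the gap lies beyond the scatter. Compound 3 (`C=C(c1cc(OC)c(OC)c(OC)c1)c1ccc(OC)c(O)c1NC(=O)CO`) differs from compound 2 by hydroxy in place of hydrogen on a saturated chain carbon bound to a carbonyl carbon with hydroxy in place of hydrogen on a saturated chain carbon bound to a carbonyl carbon, so acetamido becomes ((hydroxymethyl)carbonyl)amino. Within the data shown here, no measured pair shows this change. In this assay the expected 1.3-fold higher number from compound 2 to compound 3 (0.10 log units; within the scatter) is small, toward a higher number and within the scatter. Compound 3 is estimated at 100 nM (range 35 nM to 300 nM).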

Compound 3, half-maximal inhibitory concentration: 10 nM
Beside the measured number, compound 3's estimate is 10-fold (1.00 log units) above it; measured number below the stated range.
By their numbers in this assay, from the lowest: compound 3; then compound 2; then compound 1.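

On the acetamido chain, hydroxy in place of hydrogen on a saturated chain carbon bound to a carbonyl carbon gives an 8.0-fold lower number from compound 2 to compound 3 (0.90 log units; beyond the scatter) in this assay, a step beyond the scatter. Within the data shown here, this is the first single-place comparison, and it shows that this chain carbon is sensitive to substitution, with the added hydroxy moving the number toward stronger inhibition. Nothing at hand bears on the reason for the step.

From the compounds shown here alone, what an amine, a methoxy or a carboxylic acid would do on this carbon stays open. So does the effect of a longer chain carrying the hydroxy.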